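Swapping the Chlorophenyl Arm for a Methylpyrrole

The source may hold more compounds than are shown below. What is called first, only, known or untested is meant among the compounds shown, and "the series" means these compounds.

Among the measured compounds shown here, compound 1 `Clc1ccccc1-c1ncnc2c1cnn2CCN1CCCCC1` holds the lower of the two numbers so far in an assay on HEK293 cells for displacement of a labelled ligand from Sigma non-opioid intracellular receptor 1 (Homo sapiens), read by scintillation counting, with a stated time of 120 min (on this read-out lower numbers stand for stronger inhibition and higher numbers for weaker inhibition), giving 76 nM. Compound 2 `Cn1cc(-c2ncnc3c2cnn3CCN2CCCCC2)cn1` gives 9460 nM, and the step of a 120-fold higher number from compound 1 to compound 2 (2.10 log units; beyond the scatter) shows that putting 1-methyl-1H-pyrazol-4-yl in place of 2-chlorophenyl costs a great deal. Compound 3 `Cn1cccc1-c1ncnc2c1cnn2CCN1CCCCC1` carries 1-methyl-1H-pyrrol-2-yl in place of 2-chlorophenyl on an aromatic carbon. For the measured compounds named here, only that one step bears on it, and since the entering ring has a single hetero atom rather than two, a weaker number than compound 1 is expected, though a smaller loss than a 120-fold higher number from compound 1 to compound 2 (2.10 log units; beyond the scatter). For compound 3 the estimate is 800 nM, between 150 nM and 4000 nM, an expected step of an 11-fold higher number from compound 1 to compound 3 (1.02 log units; beyond the scatter).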

Compound 3, inhibition constant: 31 nM
For compound 3 the middle estimate is 26-fold (1.41 log units) above the measured one, and the stated range ends above it.
By their numbers in this assay, from the lowest: compound 3; then compound 1; then compound 2.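

In this assay, this aromatic carbon of the shared core accepts a five-membered aromatic ring without loss: 1-methyl-1H-pyrrol-2-yl in place of 2-chlorophenyl gives a modest gain (a 2.5-fold lower number from compound 1 to compound 3 (0.39 log units; beyond the scatter)). The earlier loss therefore does not extend to every five-membered aromatic ring, as 1-methyl-1H-pyrrol-2-yl in place of 1-methyl-1H-pyrazol-4-yl gives a large gain (a 310-fold lower number from compound 2 to compound 3 (2.48 log units; beyond the scatter)). No available evidence explains the difference between these two rings.

The compounds shown leave open whether that gap follows the hetero atoms of the ring or its point of attachment. They also leave open how an unsubstituted phenyl, or a pyrrole ring without its methyl, would fare here.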